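Trimming the amine substituent in a bradykinin receptor series

The source may hold more compounds than are shown below. What is called first, only, known or untested is meant among the compounds shown, and "the series" means these compounds.

Measured compounds:
compound 1, `CC(C)(C)CNCc1ccc2c(c1)CCC[C@H]2NC(=O)C[C@@H]1CCCCN1S(=O)(=O)c1cccc(C(F)(F)F)c1`, 59 nM
compound 2, `O=C(C[C@@H]1CCCCN1S(=O)(=O)c1cccc(C(F)(F)F)c1)N[C@@H]1CCCc2cc(CNCC3CC3)ccc21`, 16 nM

Of the compounds shown here, two sharing one core have been measured in an assay on isolated protein for inhibition of B1 bradykinin receptor (Homo sapiens); on this read-out lower numbers stand for stronger inhibition and higher numbers for weaker inhibition. Compound 1 gives 59 nM, and compound 2 gives 16 nM. Going by the values given here, the single step between them, a 3.7-fold lower number from compound 1 to compound 2 (0.57 log units; beyond the scatter), shows that changing the group on the saturated chain carbon bound to the amine nitrogen moves the read-out by a modest amount. Among the compounds with values here, compound 2 therefore stands as the lowest of the two numbers, with compound 1 the only neighbour.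

Compound 3, `O=C(C[C@@H]1CCCCN1S(=O)(=O)c1cccc(C(F)(F)F)c1)N[C@@H]1CCCc2cc(CNC3CC3)ccc21`, is the next compound in this account. It differs from compound 2 in one place: cyclopropyl in place of cyclopropylmethyl on an amine nitrogen. Within the data shown here, no measured step touches this exact change; the only step on record, a 3.7-fold lower number from compound 1 to compound 2 (0.57 log units; beyond the scatter), concerns the carbon attached to that nitrogen rather than the nitrogen itself, so it gives only a loose sense of scale. The shortening of the group by one chain carbon is expected to be tolerated, with at most a small shift, estimated as a 1.6-fold higher number from compound 2 to compound 3 (0.19 log units; within the scatter). Compound 3 is accordingly expected to give about 25 nM, within a range of 8 nM to 80 nM.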

Compound 3, half-maximal inhibitory concentration: 48 nM
Compound 3: the middle estimate sits 1.9-fold (0.28 log units) below what was measured; the range from low to high includes it.
By their numbers in this assay, from the lowest: compound 2; then compounds 3 and 1 (each within the scatter of the next).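

In this assay, taking the one chain carbon out of the cyclopropylmethyl group gives a 3.0-fold higher number from compound 2 to compound 3 (0.48 log units; beyond the scatter) and so costs a modest amount, even though both groups carry the same three-membered ring on the amine nitrogen. The ring alone therefore does not set the read-out here; whether it sits directly on the nitrogen or one saturated carbon away also matters. Cyclopropyl and neopentyl on this nitrogen are not told apart, with a 1.2-fold lower number from compound 1 to compound 3 (0.09 log units; within the scatter) lying within the scatter, so the read-out does not follow group size in one direction across these three compounds, and compound 2 alone stands apart from the other two. Nothing available explains why the one carbon matters.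

The compounds shown leave open whether the lower number of compound 2 is particular to cyclopropylmethyl or would also appear with a cyclobutylmethyl group or a longer chain such as 2-cyclopropylethyl. They also leave open what an unsubstituted amine or a simple ethyl group on this nitrogen would give, and so how much any of these substituents contributes at all.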